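Swapping the ring on the amide nitrogen of a weak inhibitor

The source may hold more compounds than are shown below. What is called first, only, known or untested is meant among the compounds shown, and "the series" means these compounds.

In a functional assay on HOS-TE85 cells (Homo sapiens) for inhibition, read by CCK-8 assay, with a stated time of 72 h (on this read-out lower numbers stand for stronger inhibition and higher numbers for weaker inhibition), compound 1 `O=C(NCCCCc1ccccc1)c1cccc(C2SCC(=O)N2c2cnccn2)c1` gives only > 1000 nM, which is a limit of the assay rather than a number (the limit of > 1000 nM in this assay, at which 1 of the 3 values shown sits). Among the compounds with values here, compound 2 `O=C(NCCCCn1cccn1)c1cccc(C2SCC(=O)N2c2ccccn2)c1` reaches 60.3 nM in this assay, and compound 3 `Cc1ccnc(N2C(=O)CSC2c2cccc(C(=O)NCCCCn3cccn3)c2)c1` reaches 19.6 nM; the only single change measured here, methyl in place of hydrogen on an aromatic carbon, gives a 3.1-fold lower number from compound 2 to compound 3 (0.49 log units; beyond the scatter). Compound 4 `C#Cc1cccc(N2C(=O)CSC2c2cccc(C(=O)NCCCCc3ccccc3)c2)c1` differs from compound 1 by 3-ethynylphenyl in place of pyrazin-2-yl on an amide-type nitrogen in a ring. Within the data shown here, no measured step touches that position, so the change from compound 1 is untested. Compound 4 is therefore expected to give roughly 800 nM in this assay, with a wide range from 100 nM to 5000 nM. That means an expected step of an at least 1.2-fold lower number from compound 1 to compound 4 (0.09 log units; that floor lies within the scatter), with a real chance that only a limit is reported again.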

Compound 4, half-maximal inhibitory concentration: 149 nM
The estimate for compound 4 lay 5.4-fold (0.73 log units) above the measured number; the measured number falls inside the stated range.
By their numbers in this assay, from the lowest: compound 3; then compound 2; then compound 4. At a limit, above all of these: compound 1.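

In this assay, within the data shown here, this is the first measured change on the amide-type ring nitrogen, and it shows that the group there matters: an at least 6.7-fold lower number from compound 1 to compound 4 (0.82 log units; beyond the scatter). With the rest of the molecule unchanged, 3-ethynylphenyl gives a measurable number where pyrazin-2-yl does not. Compound 1 stands only as a limit, so the true step could be larger: the limit of > 1000 nM in this assay, at which 1 of the 4 values shown sits.

A plain phenyl at this position would show whether the triple bond or the carbon-only ring carries the step. Also open, on these data alone, is how 3-ethynylphenyl behaves with the amide chain of compound 2.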